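This account rests on a few compounds, and the source may have more. Where it says the series, first, only, none or still open, it means among the compounds named here.

Working notes on the series.

The shared core is carried by compound 1 `COc1ccc2c(c1)OC(c1cc(OC)c(OC)c(OC)c1)C(C(=O)N1CCCCC1)=C2`, compound 2 `CCOCC1=Cc2ccc(OC)cc2OC1c1cc(OC)c(OC)c(OC)c1` and compound 3 `COc1ccc2c(c1)OC(c1cc(OC)c(OC)c(OC)c1)C=C2`. In a functional assay for inhibition of nuclear factor NF-kappa-B complex (Homo sapiens) (on this read-out higher numbers stand for weaker inhibition and lower numbers for stronger inhibition), compound 1 gives > 50000 nM, which is a limit of the assay and not a number. In this assay, for the measured compounds named here, compound 2 gives 21300 nM, the highest of the two numbers so far, while compound 3 gives 17700 nM, a value that sits within the scatter of compound 2. One of the three values shown sits at the limit of > 50000 nM in this assay, at which 1 of the 3 values shown sits.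

Of the measured steps, an at least 2.3-fold lower number from compound 1 to compound 2 (0.37 log units; beyond the scatter) and an at least 2.8-fold lower number from compound 1 to compound 3 (0.45 log units; beyond the scatter), whereas a 1.2-fold lower number from compound 2 to compound 3 (0.08 log units; within the scatter). Replacing the ethoxymethyl by hydrogen thus leaves the read-out essentially unchanged.

Compound 4 `COc1ccc2c(c1)OC(c1cc(OC)c(OC)c(OC)c1)C(C#N)=C2` is not yet measured. It differs from compound 2 by cyano in place of ethoxymethyl on a double-bonded ring carbon. Going by the values given here, the step that bears most directly on it is the one from compound 2 to compound 3, in which the ethoxymethyl is removed without a change beyond the scatter, and the cyano is a smaller group than the ethoxymethyl it replaces. In this assay, therefore, a step within the scatter is expected, with no clear direction. Compound 4 is expected to give about 18000 nM, within a range of 7000 nM to 48000 nM. The expected step of a 1.2-fold lower number from compound 2 to compound 4 (0.07 log units; within the scatter) is accordingly estimated to lie within the usual scatter.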

Compound 4, half-maximal inhibitory concentration: 3400 nM
The estimate for compound 4 lay 5.3-fold (0.72 log units) above the measured number; the measured number lies below the stated range.
By their numbers in this assay, from the lowest: compound 4; then compounds 3 and 2 (each within the scatter of the next). At a limit, above all of these: compound 1.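

In this assay, for the compounds shown here, the group on the double-bonded ring carbon turns out to matter: the earlier compounds could not separate ethoxymethyl from hydrogen here, whereas the cyano gives a 6.3-fold lower number from compound 2 to compound 4 (0.80 log units; beyond the scatter) and a 5.2-fold lower number from compound 3 to compound 4 (0.72 log units; beyond the scatter) at the same place. Among the compounds shown, the gain therefore goes with the cyano itself and not with the loss of the ethoxymethyl, since compound 3 lacks the ethoxymethyl as well and stays within the scatter of compound 2. Compound 1 stands at a limit of the assay and not at a number, so an at least 14-fold lower number from compound 1 to compound 4 (1.16 log units; beyond the scatter) gives only a lower bound on the distance between the (piperidin-1-yl)carbonyl and the cyano: the limit of > 50000 nM in this assay, at which 1 of the 4 values shown sits.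

The compounds shown leave open whether the cyano is unique at this carbon or whether other groups, such as a carboxylic acid, a methyl ester or a short chain ending in an amine, would give a similar read-out. They also leave open whether a small amide such as the dimethylamide would fall with compound 1 or with compound 4.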